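The source may hold more compounds than are shown below. What is called first, only, known or untested is meant among the compounds shown, and "the series" means these compounds.

Compound 1, `Fc1cc(Cl)ccc1-n1c(=S)n2n(c1=S)CCCC2`, gives 18.2 nM in a functional assay on the whole organism with Scenedesmus acutus as the target, read by spectrophotometry; a lower number here means a stronger inhibitor, a higher number a weaker inhibitor. Compound 2, `COC(=O)CSc1cc(-n2c(=S)n3n(c2=S)CCCC3)c(F)cc1Cl`, carries one added group, (((methoxycarbonyl)methyl)sulfanyl in place of hydrogen on an aromatic carbon), and in this assay compound 2 gives 141 nM, so that a 7.7-fold higher number from compound 1 to compound 2 (0.89 log units; beyond the scatter). Compound 3, `Fc1cc(Cl)ccc1/N=c1\sc(=S)n2n1CCCC2`, has the same atoms as compound 1 joined differently; how the two cores differ is not broken down here. In this assay compound 3 gives 67.6 nM. Compound 4, `COC(=O)CSc1cc(/N=c2\sc(=S)n3n2CCCC3)c(F)cc1Cl`, is not yet measured; it differs from compound 3 by ((methoxycarbonyl)methyl)sulfanyl in place of hydrogen on an aromatic carbon, the same change that was made from compound 1 to compound 2. Because a 7.7-fold higher number from compound 1 to compound 2 (0.89 log units; beyond the scatter), the step is expected to be of similar size on the core of compound 3, giving an expected 7.4-fold higher number from compound 3 to compound 4 (0.87 log units; beyond the scatter). Compound 4 is therefore estimated at 500 nM, within a range from 150 nM to 1600 nM.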

Compound 4, half-maximal inhibitory concentration: 191 nM
Compound 4: middle estimate off by 2.6-fold (0.42 log units), on the high side, within the range that was stated.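

In this assay, adding ((methoxycarbonyl)methyl)sulfanyl also raises the number on the second core, giving a 2.8-fold higher number from compound 3 to compound 4 (0.45 log units; beyond the scatter). The direction of the change carries over from one core to the other, but its size does not, so a step measured on one core is only a rough guide to the step on the other: the same change on two cores in this assay, a 7.7-fold higher number (0.89 log units; beyond the scatter) from compound 1 to compound 2 and a 2.8-fold higher number (0.45 log units; beyond the scatter) from compound 3 to compound 4, 2.7-fold (0.44 log units) apart, beyond the scatter of two such steps

For the compounds shown here, with only two cores compared, these results do not show why the size differs, or how the same change would behave on any further core. The compounds shown leave open whether a carboxylic acid or a longer chain in place of ((methoxycarbonyl)methyl)sulfanyl would also raise the number on both cores. They also leave open whether an amine at the same place would do so.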